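Adding chloro to compound 1

The source may hold more compounds than are shown below. What is called first, only, known or untested is meant among the compounds shown, and "the series" means these compounds.

In a functional assay on 4T1 cells (Homo sapiens) for cytotoxicity, read by MTT assay, with a stated time of 48 h (a higher number here means a weaker inhibitor, a lower number a stronger inhibitor), compound 1 `CCn1c(/C=C2/C(=O)Nc3ccccc32)nc2ccccc21` gives no number, only a limit of > 50000 nM. Compound 4 `CCn1c(/C=C2/C(=O)Nc3ccc(Cl)cc32)nc2ccccc21` keeps the core and ethyl group of compound 1 but has chloro in place of hydrogen on an aromatic carbon. Two fluoro-bearing relatives do give numbers: compound 2 `CC(C)n1c(/C=C2/C(=O)Nc3ccc(F)cc32)nc2ccccc21` gives 25800 nM and compound 3 `Cn1c(/C=C2/C(=O)Nc3ccc(F)cc32)nc2ccccc21` gives 29600 nM. Methyl in place of isopropyl on an aromatic nitrogen produced a 1.1-fold higher number from compound 2 to compound 3 (0.06 log units; within the scatter). Among the compounds with values here, no measured step covers chloro itself, so the expectation rests loosely on the values of compound 2 at 25800 nM and compound 3 at 29600 nM. The expected step is an at least 1.8-fold lower number from compound 1 to compound 4 (0.26 log units; that floor lies within the scatter), towards a stronger inhibitor. For compound 4 the estimated value is 27000 nM, with an expected range of 12000 nM to 50000 nM.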

Compound 4, half-maximal inhibitory concentration: > 50000 nM
Compound 4 was reported as a limit; the forecaster's own chance of this, stated with the estimate: 20%; at least 1.8-fold (0.26 log units) between middle value and limit.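

In this assay, compound 1 and compound 4 are both reported only as limits, so no step between them can be read: the limit of > 50000 nM in this assay, at which 2 of the 4 values shown sit.

The compounds shown leave open whether chloro in place of hydrogen on an aromatic carbon changes the cytotoxicity at all.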